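A few compounds are considered here, and "the series" means these few. Any claim that something is new, unique, unknown or untested is made for them only; others in the source may bear on it.

Measured compounds in a functional assay on SGC-7901 cells (Homo sapiens) for cytotoxicity, read by MTT assay, with a stated time of 48 h; on this read-out lower numbers stand for stronger inhibition and higher numbers for weaker inhibition:

compound 1 `Cc1ccccc1-c1nnc(SCCn2c([N+](=O)[O-])cnc2C)o1`: 32300 nM
compound 2 `COc1cc(OC)cc(-c2nnc(SCCn3c([N+](=O)[O-])cnc3C)o2)c1`: 9600 nM
compound 3 `COc1cc(-c2nnc(SCCn3c([N+](=O)[O-])cnc3C)o2)cc(OC)c1OC`: 34800 nM

Compound 1 stands second highest of the three numbers. Its value and that of compound 3 lie within the usual scatter of each other, so no order between them can be read; compound 2 gives the lower number, and that gap lies beyond the scatter.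

Within the data shown here, the only single-point step among the measured compounds is a 3.6-fold higher number from compound 2 to compound 3 (0.56 log units; beyond the scatter), a methoxy entering on an aromatic carbon of the aryl group attached to the shared core.

Compound 4 `Cc1ncc([N+](=O)[O-])n1CCSc1nnc(-c2cccs2)o1` differs from compound 1 as follows: thiophen-2-yl in place of 2-methylphenyl on an aromatic carbon. This exchanges the whole aryl group on the core rather than adding a substituent to it. Among the measured compounds shown here, the step from compound 2 to compound 3 concerns a methoxy and so does not bear on an aryl-for-aryl exchange; no measured pair has the aryl group replaced. There is therefore no measured basis for a step in either direction in this assay, and the expectation is for no change beyond the scatter, with wide uncertainty on either side.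

On that basis the expected step is a 1.2-fold lower number from compound 1 to compound 4 (0.06 log units; within the scatter). Compound 4 is thus estimated at 28000 nM in this assay, with a range from 8000 nM to 90000 nM.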

Compound 4, half-maximal inhibitory concentration: 30800 nM
The estimate for compound 4 lay 1.1-fold (0.04 log units) below the measured number; the measured number falls inside the stated range.
By their numbers in this assay, from the lowest: compound 2; then compounds 4, 1 and 3 (each within the scatter of the next).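

In this assay, among these compounds, the step of a 1.0-fold lower number from compound 1 to compound 4 (0.02 log units; within the scatter) is the first reading of an exchange of the whole aryl group on the shared core, and it lies within the scatter. Among the compounds shown here, a six-membered aromatic ring of carbon only, bearing its methyl, can thus give way at this carbon of the core to a five-membered aromatic ring with 1 hetero atom without a change that can be read here, whereas the only earlier step at this aryl group, a 3.6-fold higher number from compound 2 to compound 3 (0.56 log units; beyond the scatter), concerned a methoxy and lay beyond the scatter. This is a single pair, so it sets no pattern for aryl exchanges in general, and nothing measured on these compounds speaks to the reason for the result.

On these data alone, whether an amine or a carboxylic acid on the aryl group, or a pyridyl group in place of thiophen-2-yl, would move the number beyond the scatter stays open. Also open, as far as these compounds go, is whether a methoxy on thiophen-2-yl would give a step of the kind seen on the phenyl series, and whether a longer chain in the link to the core would alter the picture.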